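This account rests on a few compounds, and the source may have more. Where it says the series, first, only, none or still open, it means among the compounds named here.

Compound 2 `O=C(O)c1ccc(-c2cnc(C(O)CCCCCCc3ccccc3)o2)nc1` gives 45000 nM in an assay (Rattus norvegicus) for inhibition of Fatty-acid amide hydrolase 1 (Homo sapiens); on this read-out higher numbers stand for weaker inhibition and lower numbers for stronger inhibition. Among the measured compounds shown here, of the two numbers measured so far it is the highest, and the nearest neighbour is compound 1 `NC(=O)c1cnc(C(O)CCCCCCc2ccccc2)o1`, which gives 25000 nM in this assay. For the measured compounds named here, the only measured step, a 1.8-fold higher number from compound 1 to compound 2 (0.26 log units; within the scatter), exchanges a carbamoyl for a 5-carboxypyridin-2-yl on an aromatic carbon and does not reach beyond the scatter, so the two compounds cannot be ordered against each other.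

Compound 3 `NC(=O)c1ccc(-c2cnc(C(O)CCCCCCc3ccccc3)o2)nc1` is the next compound to be measured. It differs from compound 2 by amino in place of hydroxy on a carbonyl carbon; cut one bond further out, the same difference reads carboxy to carbamoyl, or 5-carboxypyridin-2-yl to 5-carbamoylpyridin-2-yl. Going by the values given here, no measured step exchanges an amino for a hydroxy on a carbonyl carbon, so nothing in the data speaks directly to this change. The step of a 1.8-fold higher number from compound 1 to compound 2 (0.26 log units; within the scatter) bears on it only loosely, in that it shows a carbamoyl-bearing compound and a carboxy-bearing compound within the scatter of each other. A step of modest size, if any, is therefore expected; compound 3 is expected to give 25000 nM in this assay, within a range from 6000 nM to 90000 nM. The expected step is a 1.8-fold lower number from compound 2 to compound 3 (0.26 log units; within the scatter).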

Compound 3, inhibition constant: 3000 nM
Beside the measured number, compound 3's estimate is 8.3-fold (0.92 log units) above it, and the stated range ends above it.
By their numbers in this assay, from the lowest: compound 3; then compounds 1 and 2 (each within the scatter of the next).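

In this assay, among the compounds shown here, amino in place of hydroxy on a carbonyl carbon gives a 15-fold lower number from compound 2 to compound 3 (1.18 log units; beyond the scatter) and is the first change to reach beyond the scatter, although the hydroxy that leaves and the amino that enters match in every count computed for them. The 5-carbamoylpyridin-2-yl group also separates from a plain carbamoyl on the aromatic carbon, with an 8.3-fold lower number from compound 1 to compound 3 (0.92 log units; beyond the scatter) as its step, whereas the 5-carboxypyridin-2-yl group did not, with a 1.8-fold higher number from compound 1 to compound 2 (0.26 log units; within the scatter) as its step, so among these three compounds the group on the carbonyl carbon decides whether the extended group gives a lower number. No evidence at hand accounts for this difference.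

On these data alone, what remains open is how specific the carbamoyl is at this place, since a methyl ester, a nitrile or an N-methyl amide could show whether the lower number of compound 3 survives any change to that group. Also open, as far as these compounds go, is whether the same step holds when the hydroxy-bearing carbon is a ketone or when the phenyl-ended chain is shorter.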